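Swapping a nitrophenyl for a dichlorophenyl on a fused core

The source may report more compounds than this note shows. Statements on the series, on what has been measured and on what is new or still open speak of the compounds shown alone.

Compound 1 `COc1ccc2cc(C(C)c3nnc4n3N=C(c3ccc([N+](=O)[O-])cc3)CS4)ccc2c1` gives 15100 nM in a functional assay on HCT-116 cells (Homo sapiens) for inhibition, read by sulforhodamine B assay, with a stated time of 72 h (a higher number here means a weaker inhibitor, a lower number a stronger inhibitor), the higher of the two numbers here; compound 2 `CC(C)Cc1ccc(C(C)c2nnc3n2N=C(c2ccc(Cl)cc2)CS3)cc1` gives 6700 nM, a lower number, beyond the scatter, though compound 2 differs from compound 1 in more than one place. Compound 3 `COc1ccc2cc(C(C)c3nnc4n3N=C(c3ccc(Cl)cc3Cl)CS4)ccc2c1` is compound 1 with 2,4-dichlorophenyl in place of 4-nitrophenyl on a carbon with a double bond to nitrogen. Within the data shown here, no single-change step is available to guide the estimate, so only a modest improvement is expected, with a 1.7-fold lower number from compound 1 to compound 3 (0.22 log units; within the scatter). Compound 3 is therefore estimated at 9000 nM, within a range from 3000 nM to 27000 nM.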

Compound 3, half-maximal inhibitory concentration: 14000 nM
Beside the measured number, compound 3's estimate is 1.6-fold (0.19 log units) below it; the measured number falls inside the stated range.
By their numbers in this assay, from the lowest: compound 2; then compounds 3 and 1 (each within the scatter of the next).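

In this assay, 2,4-dichlorophenyl in place of 4-nitrophenyl on this carbon with a double bond to nitrogen gives a 1.1-fold lower number from compound 1 to compound 3 (0.03 log units; within the scatter), so the exchange makes no difference that can be told from the scatter. Compounds 1 and 2 differ in more than one place, so they could not show this for a single change. Nothing available explains why the two groups read alike.

From the compounds shown here alone, whether an amine or a carboxylic acid on this carbon would give a clearly different number remains open. So does which part of compound 2 goes with its lower number.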